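The source may report more compounds than this note shows. Statements on the series, on what has been measured and on what is new or still open speak of the compounds shown alone.

Compound 1 `O=c1cc(-c2ccccc2)oc2cc(OCc3ccccc3)c(OCCCCN3CCCCC3)c(O)c12` is a flavone carrying a benzyl ether and a piperidine-terminated chain on its core. In a functional assay on A549 cells (Homo sapiens) for antiproliferative activity, read by MTT assay, with a stated time of 48 h (a lower number here means a stronger inhibitor, a higher number a weaker inhibitor), compound 1 gives 1900 nM, the lower of the two numbers recorded here. Among the compounds with values here, its only measured neighbour, compound 2 `O=c1cc(-c2ccccc2)oc2cc(O)c(OCCCCN3CCCCC3)c(O)c12`, differs by a single change and in this assay compound 2 gives 75000 nM; the step of a 39-fold higher number from compound 1 to compound 2 (1.60 log units; beyond the scatter) shows how much that one position matters.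

Compound 3 `CN(C)CCCOc1c(OCc2ccccc2)cc2oc(-c3ccccc3)cc(=O)c2c1O` keeps the benzyl ether of compound 1 and alters the other side chain instead: dimethylamino in place of (piperidin-1-yl)methyl on a saturated chain carbon, three bonds along the chain from an oxygen on an aromatic ring. Within the data shown here, no measured step touches this part of the molecule, so the pair of compound 1 and compound 2, which concerns the benzyl ether alone, does not speak to it directly. The expectation for compound 3 therefore rests on the structural change itself, with the chain and its basic amine retained and only the ring around the nitrogen replaced by two methyl groups, and compound 3 is expected to sit close to compound 1, with the step of a 1.6-fold higher number from compound 1 to compound 3 (0.20 log units; within the scatter) estimated to remain within the scatter or a little beyond it. In this assay compound 3 is thus estimated at 3000 nM, within a range from 800 nM to 12000 nM.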

Compound 3, half-maximal inhibitory concentration: 2600 nM
The estimate for compound 3 lay 1.2-fold (0.06 log units) above the measured number; measured number inside the range.
By their numbers in this assay, from the lowest: compounds 1 and 3 (each within the scatter of the next); then compound 2.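

In this assay, the exchange of 4-(piperidin-1-yl)butyl for 3-(dimethylamino)propyl gives a 1.4-fold higher number from compound 1 to compound 3 (0.14 log units; within the scatter), so the two compounds cannot be told apart at this end of the molecule. That contrasts with the benzyl ether, where a 39-fold higher number from compound 1 to compound 2 (1.60 log units; beyond the scatter) showed a large step, and it means that on this core the six-membered non-aromatic ring can be exchanged for dimethylamino, with a different chain length, without the number leaving the scatter. No information is available that would explain why this side chain accepts the change while the benzyl ether position does not.

Within the data shown here, the single step alters the amine and the chain length together, so the share of each remains unresolved, and how a morpholine ring, a primary amine, a longer chain or a terminal carboxylic acid would read in this assay stays open. As far as these compounds go, it is also open whether hydrogen in place of benzyl would cost as much on the 3-(dimethylamino)propyl chain of compound 3 as it does on the 4-(piperidin-1-yl)butyl chain of compound 1.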